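A few compounds are considered here, and "the series" means these few. Any claim that something is new, unique, unknown or untested is made for them only; others in the source may bear on it.

Among the measured compounds shown here, in a functional assay on DU-145 cells (Homo sapiens) for cytotoxicity, read by trypan blue exclusion, with a stated time of 96 h (on this read-out higher numbers stand for weaker inhibition and lower numbers for stronger inhibition), compound 3 `COc1ccc(CS(=O)(=O)/C=C/c2c(OC)cccc2OC)c(N)c1` gives 750 nM, the lowest of the three numbers so far, with compound 1 `COc1cc(OC)c(/C=C/S(=O)(=O)Cc2ccc(F)c(N)c2)c(OC)c1` at 2500 nM and compound 2 `COc1ccc(CS(=O)(=O)/C=C/c2c(OC)cccc2OC)c([N+](=O)[O-])c1` at 50000 nM. Next is compound 4 `COc1ccc(CS(=O)(=O)/C=C/c2c(OC)cc(OC)cc2OC)c(N)c1`, with methoxy in place of hydrogen on an aromatic carbon. For the measured compounds named here, the only measured step, a 67-fold lower number from compound 2 to compound 3 (1.82 log units; beyond the scatter), is large but is amino in place of nitro, a different change, and sets no size for this one. Compound 1 also holds the entering methoxy but differs from compound 3 in other places too, so no clean comparison exists. With little support, the estimated move in this assay is modest and towards a lower number: a 2.5-fold lower number from compound 3 to compound 4 (0.40 log units; beyond the scatter). For compound 4 the expected value is 300 nM, with an estimated range of 60 nM to 1500 nM.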

Compound 4, half-maximal inhibitory concentration: 25 nM
For compound 4 the middle estimate is 12-fold (1.08 log units) above the measured one; measured number outside the range, below it.
By their numbers in this assay, from the lowest: compound 4; then compound 3; then compound 1; then compound 2.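

In this assay, methoxy in place of hydrogen, on the aromatic carbon para to a large group and meta to two methoxy groups, proves a large change at this position: a 30-fold lower number from compound 3 to compound 4 (1.48 log units; beyond the scatter). With that ring held constant, 2-amino-4-methoxyphenyl in place of 3-amino-4-fluorophenyl on the saturated chain carbon gives a 100-fold lower number from compound 1 to compound 4 (2.00 log units; beyond the scatter), so this second site also moves the number strongly. Nothing available accounts for either step.

From the compounds shown here alone, whether an ethoxy group, a chlorine atom or a hydroxyl group at this position would match methoxy remains open. Also open, going by these compounds, is whether the methoxy step holds without the amino group, as it is seen only from compound 3.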